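Amide Variation on a Shared Dihydroxyheptanoic Acid Core

The source may report more compounds than this note shows. Statements on the series, on what has been measured and on what is new or still open speak of the compounds shown alone.

Measured in an assay on microsomes from liver for inhibition of 3-hydroxy-3-methylglutaryl-coenzyme A reductase (Rattus norvegicus); on this read-out lower numbers stand for stronger inhibition and higher numbers for weaker inhibition:
- compound 1 `CC(C)c1c(C(=O)N2CCC[C@H](c3ccccc3)C2)nn(-c2ccc(F)cc2)c1OC[C@@H](O)C[C@@H](O)CC(=O)O`: 4.8 nM
- compound 2 `COc1ccc(CNC(=O)c2nn(-c3ccc(F)cc3)c(OC[C@@H](O)C[C@@H](O)CC(=O)O)c2C(C)C)cc1`: 12 nM
- compound 3 `CC(C)c1c(C(=O)NCc2ccc(Cl)cc2)nn(-c2ccc(F)cc2)c1OC[C@@H](O)C[C@@H](O)CC(=O)O`: 6.7 nM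

Compound 3 stands second highest of the three numbers in this assay; its nearest neighbour is compound 1 and its furthest compound 2, and both gaps sit within the scatter, so no order among the three is secure.

Compound 4 `CC(C)c1c(C(=O)N(C)Cc2cccc(Cl)c2)nn(-c2ccc(F)cc2)c1OC[C@@H](O)C[C@@H](O)CC(=O)O` differs from compound 3 at the amide: (3-chlorobenzyl)(methyl)amino in place of (4-chlorobenzyl)amino on a carbonyl carbon. Going by the values given here, three measured steps bear on this. The amide substituent was varied in a 2.5-fold higher number from compound 1 to compound 2 (0.40 log units; beyond the scatter) and in a 1.4-fold higher number from compound 1 to compound 3 (0.14 log units; within the scatter), the first modest, the second within the scatter, and the aromatic substituent in a 1.8-fold lower number from compound 2 to compound 3 (0.25 log units; within the scatter), within the scatter. Compound 1, a tertiary amide, gives the lowest number, so loss of the amide hydrogen is not expected to cost potency. The step is therefore expected to be small, a 1.2-fold higher number from compound 3 to compound 4 (0.08 log units; within the scatter), with no secure direction.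

Compound 4 is expected to give about 8 nM in this assay, within 3 nM to 25 nM.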

Compound 4, half-maximal inhibitory concentration: 8.3 nM
Estimate against measurement, compound 4: 1.0-fold (0.02 log units) below, and the stated range covers the measured number.
By their numbers in this assay, from the lowest: compounds 1, 3, 4 and 2 (each within the scatter of the next, the first and the last beyond it).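

In this assay, (3-chlorobenzyl)(methyl)amino in place of (4-chlorobenzyl)amino on the carbonyl carbon gives a 1.2-fold higher number from compound 3 to compound 4 (0.09 log units; within the scatter) so this double change, which removes the amide hydrogen and moves the chloro group, produces no readable shift. The same group also stays within the scatter of the other two amides, with a 1.4-fold lower number from compound 2 to compound 4 (0.16 log units; within the scatter) and a 1.7-fold higher number from compound 1 to compound 4 (0.24 log units; within the scatter) even though the step between those two compounds lies beyond the scatter. Nothing presented here accounts for this result.

The compounds shown leave open what the methyl group and the chloro placement each do alone, which (3-chlorobenzyl)amino and (4-chlorobenzyl)(methyl)amino would separate. Going by these compounds, how a longer chain such as (2-phenylethyl)amino on the carbonyl carbon would read also remains open.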